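Fluoro for methoxy on a triazole thioether series

The source may hold more compounds than are shown below. What is called first, only, known or untested is meant among the compounds shown, and "the series" means these compounds.

Measured so far:
compound 1 `COc1ccc(CSc2nnc(-c3cc(OC)c(OC)c(OC)c3)n2-c2ccc(N(C)C)cc2)cc1`, > 60000 nM
compound 2 `COc1cc(-c2nnc(SCc3ccc(F)cc3)n2-c2ccc(N(C)C)cc2)cc(OC)c1OC`, 26400 nM
compound 3 `COc1ccc(C(=O)CSc2nnc(-c3cc(OC)c(OC)c(OC)c3)n2-c2ccc(N(C)C)cc2)cc1`, 18800 nM

All three were tested in a functional assay on HepG2 cells (Homo sapiens) for inhibition, read by MTT assay, with a stated time of 48 h; on this read-out lower numbers stand for stronger inhibition and higher numbers for weaker inhibition. For compound 1 the result is a limit of the assay and not a number, (the limit of > 60000 nM in this assay, at which 1 of the 3 values shown sits). Compound 2 differs from compound 1 by fluoro in place of methoxy on an aromatic carbon, and this gave an at least 2.2-fold lower number from compound 1 to compound 2 (0.35 log units; beyond the scatter). Compound 3 differs from compound 1 by (4-methoxyphenyl)carbonyl in place of 4-methoxyphenyl on a saturated chain carbon bound to a sulfur, which gave an at least 3.1-fold lower number from compound 1 to compound 3 (0.50 log units; beyond the scatter). Between compound 2 and compound 3 the step is a 1.4-fold lower number from compound 2 to compound 3 (0.15 log units; within the scatter).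

Compound 4 `COc1cc(-c2nnc(SCC(=O)c3ccc(F)cc3)n2-c2ccc(N(C)C)cc2)cc(OC)c1OC` is not yet measured. It differs from compound 3 by fluoro in place of methoxy on an aromatic carbon, the same change that was made from compound 1 to compound 2, at the same place. Because that earlier step was an at least 2.2-fold lower number from compound 1 to compound 2 (0.35 log units; beyond the scatter) and started from a limit, its true size is not known, so the expectation for compound 4 rests on that step only loosely. Compound 4 is expected to give a step of a 1.6-fold lower number from compound 3 to compound 4 (0.19 log units; within the scatter). Compound 4 is thus estimated at 12000 nM, with a range from 5000 nM to 30000 nM.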

Compound 4, half-maximal inhibitory concentration: > 60000 nM
Compound 4: a limit, no number; the forecaster's own chance of this, stated with the estimate: 5%; at least 5.0-fold (0.69 log units) between middle value and limit.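

Carried to the core of compound 3, fluoro in place of methoxy on an aromatic carbon gave an at least 3.1-fold higher number from compound 3 to compound 4 (0.50 log units; beyond the scatter) in this assay, the opposite direction to the earlier step, so the change did not carry over from one core to the other: the same change on two cores in this assay, an at least 2.2-fold lower number (0.35 log units; beyond the scatter) from compound 1 to compound 2 and an at least 3.1-fold higher number (0.50 log units; beyond the scatter) from compound 3 to compound 4, at least 7.2-fold (0.86 log units) apart, beyond the scatter of two such steps Viewed from the other side of the same pair of cores, (4-fluorophenyl)carbonyl in place of 4-fluorophenyl gave an at least 2.2-fold higher number from compound 2 to compound 4 (0.35 log units; beyond the scatter). The reversal is thus clear in direction, but its true size and its cause are not shown, and the step from compound 1 to compound 4 cannot be read, as both values are limits of the assay and not numbers: the limit of > 60000 nM in this assay, at which 2 of the 4 values shown sit.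

The compounds shown leave open whether the reversal is specific to fluoro or would also appear with chloro or a nitrile on the same aromatic carbon. On these data alone, it also remains open how an amine or a carboxylic acid in that place would read on either core.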